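Methylating the phenol of compound 2

The compounds below may be only part of what the source reports. "The series", "measured", "known", "first", "only" and "open" are said of these compounds alone.

Compound 2 `O=C(/C=C/c1ccc(O)c(O)c1)c1ccc(O)cc1` gives 4 nM in an assay on RBL-1 cells for inhibition of Polyunsaturated fatty acid 5-lipoxygenase (Rattus norvegicus) (on this read-out higher numbers stand for weaker inhibition and lower numbers for stronger inhibition), the lowest of the three numbers recorded there. Compound 1 `O=C(/C=C/c1ccc(O)c(O)c1)c1cccc(O)c1` gives 4.2 nM, within the scatter of compound 2, whereas compound 3 `Cc1cccc(C(=O)/C=C/c2ccc(O)c(O)c2)c1` gives 27 nM, beyond it. For the measured compounds named here, the only single-point step measured, a 6.4-fold higher number from compound 1 to compound 3 (0.81 log units; beyond the scatter), replaces a hydroxy on an aromatic carbon with methyl. Compound 4 `COc1ccc(C(=O)/C=C/c2ccc(O)c(O)c2)cc1` differs from compound 2 by methyl in place of hydrogen on an oxygen on an aromatic ring. The hydroxy is lost in both changes, though methoxy is not methyl, so a modest upward step of similar or somewhat smaller size is expected in this assay; because of a 6.4-fold higher number from compound 1 to compound 3 (0.81 log units; beyond the scatter) the expected step is a 3.8-fold higher number from compound 2 to compound 4 (0.57 log units; beyond the scatter). For compound 4 the estimate is 15 nM, with a range of 5 nM to 50 nM.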

Compound 4, half-maximal inhibitory concentration: 20 nM
Estimate against measurement, compound 4: 1.3-fold (0.12 log units) below; low and high end bracket the measured number.
By their numbers in this assay, from the lowest: compounds 2 and 1 (each within the scatter of the next); then compounds 4 and 3 (each within the scatter of the next).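

In this assay, replacing hydroxy with methoxy on this aromatic ring keeps the oxygen in place, yet the number still moves beyond the scatter: a 5.0-fold higher number from compound 2 to compound 4 (0.70 log units; beyond the scatter). At this position, therefore, retaining the oxygen is not enough to keep the number of compound 2; the hydrogen on it counts as well. No evidence here bears on the reason for this step. Still open, from the compounds shown here alone, is whether a longer chain on this oxygen or an amine in place of the hydroxy would give a higher or lower number.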